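Geometry Change at the Enamide Double Bond

The source may hold more compounds than are shown below. What is called first, only, known or untested is meant among the compounds shown, and "the series" means these compounds.

Three compounds were measured in an ADME assay on HEK293 cells (Homo sapiens) for inhibition, read by CellTiter-Glo, with a stated time of 96 h, tested at 100 uM; a higher number here means more inhibition at the concentration tested (going by the name of the read-out), a lower number less inhibition. Compound 1 `CCOC(=O)/C=C/NC(=O)[C@H](O)C(C)(C)CO` gives -5%, compound 2 `CC(C)(CO)[C@H](O)C(=O)N/C=C/C(=O)OCc1ccccc1` gives -6%, and compound 3 `CC(C)(C)OC(=O)/C=C/NC(=O)[C@@H](O)C(C)(C)CO` gives -8%; all three numbers sit near zero and within the scatter of one another, so compound 1 stands with the other two rather than apart from them. For the measured compounds named here, the one measured step, a number 2 percentage points lower from compound 2 to compound 3 (within the scatter), stayed within the scatter. Compound 4 `CCOC(=O)/C=C\NC(=O)[C@H](O)C(C)(C)CO` differs from compound 1 only in this: the two compounds have the same atoms and bonds and differ only in configuration as drawn: 1 of 2 stereo elements differ; a double bond is drawn E in compound 1 and Z in compound 4. Going by the values given here, no measured step covers such a change of drawn geometry, and every number so far is close to zero. Compound 4 is therefore expected to give -5%, within a range from -15% to 5%. The expected step is no change at the digits printed from compound 1 to compound 4 (within the scatter), none beyond the scatter.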

Compound 4, a percentage reported as inhibition, at one concentration (the size of the read-out at that concentration, not a potency): -6%
Estimate against measurement, compound 4: 1 percentage points above, within the range that was stated.
By their numbers in this assay, from the lowest: compounds 3, 2, 4 and 1 (each within the scatter of the next).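

In this assay, the geometry of the enamide double bond now has a measured step of its own, a number 1 percentage points lower from compound 1 to compound 4 (within the scatter), so the E and Z forms cannot be told apart here. The earlier step concerned only the group on the oxygen next to a carbonyl group, not this bond. This comparison isolates a single feature: the fact that compounds 1 and 4 differ only in the configuration as drawn

All the numbers lie near zero, so the compounds shown do not say whether this geometry would matter in a compound giving clear inhibition. They also leave open what a carboxylic acid or an amine in place of the ester would give.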